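The source may hold more compounds than are shown below. What is called first, only, known or untested is meant among the compounds shown, and "the series" means these compounds.

Compound 1 `COC(=O)N[C@H](C(=O)NN(CCC[C@@](O)(Cc1ccccc1)C(=O)N[C@H]1c2ccccc2C[C@H]1O)Cc1ccccc1)C(C)(C)C` gives > 10000 nM in an ADME assay on MT4 cells (Homo sapiens) for cytotoxicity (a higher number here means that more compound is tolerated, a lower number that less compound is tolerated), a limit of the assay.
Compound 2 `COC(=O)N[C@H](C(=O)NN(CCC[C@@](O)(Cc1ccccc1)C(=O)N[C@H]1c2ccccc2C[C@H]1O)Cc1ccc(Cl)cc1)C(C)(C)C` gives > 10000 nM in this assay, likewise a limit.
Compound 3 `COC(=O)N[C@H](C(=O)NN(CCC[C@@](O)(Cc1ccccc1)C(=O)N[C@H]1c2ccccc2C[C@H]1O)Cc1ccc(-c2cncnc2)cc1)C(C)(C)C` gives > 10000 nM in this assay, again a limit.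

Compound 2 thus stands at the same limit as the other two, and none of the three shows a number. The change to compound 4 `COC(=O)N[C@H](C(=O)NN(CCC[C@@](O)(Cc1ccccc1)C(=O)N[C@H]1c2ccccc2C[C@H]1O)Cc1ccc(-c2csc(C)n2)cc1)C(C)(C)C` is 2-methyl-1,3-thiazol-4-yl in place of chloro on an aromatic carbon. The steps a step that the two limits leave unreadable from compound 1 to compound 2, a step that the two limits leave unreadable from compound 1 to compound 3 and a step that the two limits leave unreadable from compound 2 to compound 3 are all unreadable because of the limit of > 10000 nM in this assay, at which 3 of the 3 values shown sit. With every shown value sitting at that limit, compound 4 is expected to show no readable step, a step that the limit leaves unreadable from compound 2 to compound 4, and most likely another limit. Compound 4 is estimated at 15000 nM, between 7000 nM and 40000 nM.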

Compound 4, half-maximal cytotoxic concentration: > 10000 nM
Compound 4: no number, only a limit (the forecaster's own chance of this, stated with the estimate: 85%); the middle value lies beyond the limit too.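

Among these compounds, no step from compound 1, compound 2 or compound 3 to compound 4 can be read, because all four stand at one limit: the limit of > 10000 nM in this assay, at which 4 of the 4 values shown sit.
The compounds shown leave open in this assay whether these aromatic substituents differ at all, since none gives a number.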